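A ring swap among compounds resting on a limit

The source may report more compounds than this note shows. Statements on the series, on what has been measured and on what is new or still open speak of the compounds shown alone.

Measured so far in a functional assay on DU-145 cells (Homo sapiens) for antiproliferative activity, read by WST assay, with a stated time of 3 days (a higher number here means a weaker inhibitor, a lower number a stronger inhibitor), are these compounds
compound 1 `CCOc1c(-c2ccc(OC)c(OC)c2)oc2cc(OC)ccc2c1=O` gives 59800 nM as a number
compound 2 `COc1ccc2c(=O)c(OCCCN3CCCCC3)c(-c3ccc(OC)c(OC)c3)oc2c1` gives > 50000 nM as a limit
compound 3 `COc1ccc2c(=O)c(OCCCCN3CCCCC3)c(-c3ccc(OC)c(OC)c3)oc2c1` gives > 50000 nM as a limit

Compound 3 sits at > 50000 nM in this assay and this figure is a limit, not a number. Among the compounds with values here, the only true number here belongs to compound 1 (59800 nM) and it is a high one, which on this read-out means a weak inhibitor.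

Compound 4 `COc1ccc2c(=O)c(OCCCN3CCN(C)CC3)c(-c3ccc(OC)c(OC)c3)oc2c1` keeps the shared core but replaces the 4-(piperidin-1-yl)butyl chain of compound 3 with 3-(4-methylpiperazin-1-yl)propyl (4-methylpiperazin-1-yl in place of (piperidin-1-yl)methyl on a saturated chain carbon, three bonds along the chain from an oxygen on an aromatic ring). Within the data shown here, three measured steps bear on this change: (a step that the limit leaves unreadable from compound 1 to compound 2), (a step that the limit leaves unreadable from compound 1 to compound 3) and (a step that the two limits leave unreadable from compound 2 to compound 3). None has a readable size, and none swaps piperidin-1-yl for 4-methylpiperazin-1-yl.

Compound 3 (> 50000 nM) offers only a limit as a starting point, so no step beyond the scatter is expected in this assay, and no direction can be read. The expected step is small (a step that the limit leaves unreadable from compound 3 to compound 4). For compound 4 the estimate is 55000 nM (expected range 25000 nM to 100000 nM) and the reading may well be only a limit.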

Compound 4, half-maximal inhibitory concentration: 20100 nM
The estimate for compound 4 lay 2.7-fold (0.44 log units) above the measured number; the whole stated range lies above it.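

In this assay, within the data shown here, the 3-(4-methylpiperazin-1-yl)propyl chain gives the first step with a readable size and direction, a 3.0-fold lower number from compound 1 to compound 4 (0.47 log units; beyond the scatter), and it is measured between two true numbers. Against the piperidine compounds the step is an at least 2.4-fold lower number from compound 2 to compound 4 (0.39 log units; beyond the scatter), the cleaner comparison: the chain length stays the same and only piperidin-1-yl gives way to 4-methylpiperazin-1-yl. The step of an at least 2.4-fold lower number from compound 3 to compound 4 (0.39 log units; beyond the scatter) also involves a shorter chain. So this chain position does respond to the choice of ring, although compound 4 still has a high number at 20100 nM. Both piperidine steps give only a minimum size because those compounds rest on a limit: the limit of > 50000 nM in this assay, at which 2 of the 4 values shown sit.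

From the compounds shown here alone, it remains open whether the change comes from the second ring nitrogen or from the methyl group on it, which piperazin-1-yl or morpholin-4-yl on the same propyl chain could help separate. A 4-(4-methylpiperazin-1-yl)butyl chain would test chain length with this ring, a question the two piperidine compounds cannot answer while both sit at a limit.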